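A few compounds are considered here, and "the series" means these few. Any claim that something is new, unique, unknown or untested is made for them only; others in the source may bear on it.

Among the compounds with values here, in a functional assay on Ramos cells (Homo sapiens) for antiproliferative activity, read by CCK-8 assay, with a stated time of 72 h (on this read-out lower numbers stand for stronger inhibition and higher numbers for weaker inhibition), compound 2 `CCOC(=O)c1sc(-c2cccc(NC(=O)c3ccccc3F)c2)nc1Nc1ccc(N2CCN(C)CC2)cc1` gives 2000 nM, the lowest of the two numbers so far, while compound 1 `CCOC(=O)c1sc(-c2cccc(NC(=O)c3cccc(F)c3)c2)nc1Nc1ccc(N2CCN(C)CC2)cc1` gives 12800 nM. Within the data shown here, the single measured step, a 6.4-fold lower number from compound 1 to compound 2 (0.81 log units; beyond the scatter), is all there is to go on. Compound 3 `CCOC(=O)c1sc(-c2cccc(NC(=O)c3ccc(C#N)cc3)c2)nc1Nc1ccc(N2CCN(C)CC2)cc1` carries 4-cyanophenyl in place of 2-fluorophenyl on a carbonyl carbon. That one step shows a change of the ring substituent alone moving this assay beyond the scatter, so an upward shift is anticipated here, since compound 1 with 3-fluorophenyl at the same place gave 12800 nM. Compound 3 is therefore expected near 6000 nM, between 1500 nM and 25000 nM. The expected step is a 3.0-fold higher number from compound 2 to compound 3 (0.48 log units; beyond the scatter).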

Compound 3, half-maximal inhibitory concentration: 4280 nM
For compound 3 the middle estimate is 1.4-fold (0.15 log units) above the measured one; the measured number falls inside the stated range.
By their numbers in this assay, from the lowest: compound 2; then compound 3; then compound 1.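

In this assay, the change to 4-cyanophenyl on a carbonyl carbon gives a 2.1-fold higher number from compound 2 to compound 3 (0.33 log units; beyond the scatter), but also a 3.0-fold lower number from compound 1 to compound 3 (0.48 log units; beyond the scatter). This position therefore takes a substituent other than fluorine, and the number of compound 3 falls within the span set by the two fluorophenyl compounds. No available evidence accounts for this order.

The compounds shown leave open whether the nitrile itself or its place on the ring sets the number, since the ring position and the substituent change together here. Going by these compounds, how an amine or a carboxylic acid on this ring would read also remains open.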